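Cytotoxicity in the diaryl ether uracil series: isopropyl to methoxymethyl

The compounds below may be only part of what the source reports. "The series", "measured", "known", "first", "only" and "open" are said of these compounds alone.

Compound 3 `Cc1c(Oc2ccccc2OCCn2ccc(=O)[nH]c2=O)cc(C(C)C)c2ccc(C#N)cc12` gives the lowest of the two numbers in a toxicity assay on MT2 cells (Homo sapiens) for cytotoxicity, read by MTT assay; a higher number here means that more compound is tolerated, a lower number that less compound is tolerated; compound 1 `N#Cc1ccc2c(Cl)cc(Oc3ccccc3OCCn3ccc(=O)[nH]c3=O)cc2c1` gives 12000 nM, which lies within the scatter of compound 3 at 9000 nM. For compound 2 `Cc1cc(Oc2ccccc2OCCn2ccc(=O)[nH]c2=O)c(C)c2cc(C#N)ccc12` the assay reports only a limit, > 100000 nM (the limit of > 100000 nM in this assay, at which 1 of the 3 values shown sits). Compound 4 `COCc1cc(Oc2ccccc2OCCn2ccc(=O)[nH]c2=O)c(C)c2cc(C#N)ccc12` differs from compound 3 by methoxymethyl in place of isopropyl on an aromatic carbon. Among the measured compounds shown here, the one measured step that touches this position, an at least 11-fold lower number from compound 2 to compound 3 (1.04 log units; beyond the scatter), shows that the group here moves the number strongly. Methoxymethyl is neither methyl nor isopropyl, so the size of its effect is open; a moderately higher number than compound 3 is expected, and compound 4 is estimated at 20000 nM (range 6000 nM to 80000 nM), corresponding to an expected step of a 2.2-fold higher number from compound 3 to compound 4 (0.35 log units; beyond the scatter).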

Compound 4, half-maximal cytotoxic concentration: 16000 nM
Beside the measured number, compound 4's estimate is 1.3-fold (0.10 log units) above it; measured number inside the range.
By their numbers in this assay, from the lowest: compounds 3, 1 and 4 (each within the scatter of the next). At a limit, above all of these: compound 2.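

In this assay, methoxymethyl and isopropyl on this aromatic carbon, each of 3 heavy atoms, give numbers that cannot be told apart (a 1.8-fold higher number from compound 3 to compound 4 (0.25 log units; within the scatter)). Methoxy in place of hydrogen on the methyl group of compound 2 is enough to bring the number down from the limit (an at least 6.2-fold lower number from compound 2 to compound 4 (0.79 log units; beyond the scatter)). Compound 2 gives only a limit, > 100000 nM, so the full size of that step cannot be read.

On these data alone, whether an amine or a carboxylic acid on this carbon would separate from these values stays open. A longer ether chain is open as well.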